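The source may hold more compounds than are shown below. What is called first, only, known or untested is meant among the compounds shown, and "the series" means these compounds.

So far, two compounds sharing one core have been tested in a functional assay on MGC-803 cells (Homo sapiens) for cytotoxicity, read by MTT assay, with a stated time of 72 h (on this read-out lower numbers stand for stronger inhibition and higher numbers for weaker inhibition), and compound 1 `O=C1C(=Cc2ccc(F)cc2)C(=O)N(c2ccc(Cl)cc2)N1c1ccc(Cl)cc1` gives 26000 nM there, while compound 2 `COc1cccc(C=C2C(=O)N(c3ccc(Cl)cc3)N(c3ccc(Cl)cc3)C2=O)c1O` gives 24300 nM on the same read-out. These two numbers lie within the scatter of each other, so compound 2 stands level with compound 1 and neither can be ranked above the other.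

Compound 3 `COc1ccc(C=C2C(=O)N(c3ccc(Cl)cc3)N(c3ccc(Cl)cc3)C2=O)cc1` has not been measured yet. It carries 4-methoxyphenyl in place of 2-hydroxy-3-methoxyphenyl on a double-bonded chain carbon bound to a double-bonded ring carbon. Among the compounds with values here, only one measured step bears on this place. Putting 2-hydroxy-3-methoxyphenyl in place of 4-fluorophenyl there gave a 1.1-fold lower number from compound 1 to compound 2 (0.03 log units; within the scatter) and so made no difference that can be told from noise. That is thin evidence from a single pair, but it gives no reason to expect a shift beyond the scatter in this assay in either direction. The estimated change is a 1.0-fold higher number from compound 2 to compound 3 (0.01 log units; within the scatter) and is expected to be no real change. For compound 3 the expected value is 25000 nM with an estimated range from 12000 nM to 50000 nM for repeated measurements.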

Compound 3, half-maximal inhibitory concentration: > 128000 nM
Compound 3: a limit, no number; the forecaster's own chance of this, stated with the estimate: 10%; at least 5.1-fold (0.70 log units) between middle value and limit.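

In this assay compound 3 gives only a limit of the assay, not a number: the limit of > 128000 nM in this assay, at which 1 of the 3 values shown sits. The place on the double-bonded chain carbon therefore does respond to change, which the first pair could not show: 4-methoxyphenyl in place of 2-hydroxy-3-methoxyphenyl gives an at least 5.2-fold higher number from compound 2 to compound 3 (0.72 log units; beyond the scatter), and methoxy in place of fluoro on an aromatic carbon gives an at least 4.9-fold higher number from compound 1 to compound 3 (0.69 log units; beyond the scatter). Compound 2 also carries a methoxy group, and it stands level with compound 1, so the presence of a methoxy group on this ring does not by itself set the result.

The step to 4-methoxyphenyl removes the hydroxy group and moves the methoxy group at once, so these compounds cannot show which of the two changes matters, and 2-hydroxyphenyl or 3-methoxyphenyl at this place would separate them. They also leave open how an amine or a carboxylic acid on this ring would read, and whether any group here can bring the numbers far below those of compound 1 and compound 2.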